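The compounds below may be only part of what the source reports. "The series", "measured", "known", "first", "only" and "open" are said of these compounds alone.

Compound 1 `COc1ccc(-c2cnc(NC(=O)c3ccc(Br)cc3)n2C)cc1` was tested in a toxicity assay on THP-1 cells (Homo sapiens) for inhibition; a lower number here means that less compound is tolerated, a higher number that more compound is tolerated. In that test compound 1 gives > 100000 nM, which is a limit of the assay rather than a measured number. Compound 2 `COc1ccc(-c2ccnc(NC(=O)c3ccc(F)cc3)c2)cc1` in this assay gives > 100000 nM, also a limit. Compound 3 `Cn1c(-c2ccccc2)cnc1NC(=O)c1ccc(Br)cc1` in this assay gives > 100000 nM, again a limit. Compound 1 thus stands where every measured compound stands: the limit of > 100000 nM in this assay, at which 3 of the 3 values shown sit. Going by the values given here, the only one-place step among the measured compounds, a step that the two limits leave unreadable from compound 1 to compound 3, is left without a readable size by the two limits at its ends.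

Compound 4 `COc1ccc(-c2cnc(NC(=O)c3ccccc3)n2C)cc1` has not yet been measured; it differs from compound 1 in one place: hydrogen in place of bromo on an aromatic carbon. Among the compounds with values here, no measured step follows this particular change, and the one step that exists, a step that the two limits leave unreadable from compound 1 to compound 3, offers no size to borrow. With every measured value sitting at the limit, no step beyond the usual scatter in this assay is expected in either direction. Compound 4 is therefore estimated at 100000 nM, with a range from 30000 nM to 300000 nM. The expected step of a number no higher from compound 1 to compound 4 (the limit leaves the size open) would most likely be reported only as a limit again.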

Compound 4, half-maximal cytotoxic concentration: > 100000 nM
Compound 4: no number, only a limit (the forecaster's own chance of this, stated with the estimate: 80%); the middle value sits exactly at the limit.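

Compound 1 and compound 4 both end at a limit of the assay rather than at a number, so no size can be read for the change from bromo to hydrogen: the limit of > 100000 nM in this assay, at which 4 of the 4 values shown sit. The compounds shown leave open what actual toxic concentration any of them has in this assay, and whether any single change alters it.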